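The compounds below may be only part of what the source reports. "The series", "measured", "known", "first", "only" and "open" are said of these compounds alone.

Measured so far in an ADME assay on THP-1 cells (Homo sapiens) for cytotoxicity; on this read-out higher numbers stand for weaker inhibition and lower numbers for stronger inhibition: compound 1 `COc1ccccc1-c1nnc(-c2ccc(C(=O)N/N=C/c3cccc(O)c3)cc2)o1` gives 398000 nM; compound 2 `COc1ccccc1-c1nnc(-c2ccc(C(=O)N/N=C/c3cccc([N+](=O)[O-])c3)cc2)o1` gives 119000 nM; compound 3 `COc1ccccc1-c1nnc(-c2ccc(C(=O)N/N=C/c3cccnc3)cc2)o1` gives 167000 nM.

Compound 3 stands second highest of the three numbers. Its nearest neighbour is compound 2, as the step of a 1.4-fold higher number from compound 2 to compound 3 (0.15 log units; within the scatter) shows, which lies within the scatter; the gap to compound 1, given by the step of a 2.4-fold lower number from compound 1 to compound 3 (0.38 log units; beyond the scatter), lies beyond it.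

The next compound, compound 4 `COc1ccc(O)c(/C=N/NC(=O)c2ccc(-c3nnc(-c4ccccc4OC)o3)cc2)c1`, carries a single change relative to compound 3: 2-hydroxy-5-methoxyphenyl in place of pyridin-3-yl on a carbon with a double bond to nitrogen.

For the measured compounds named here, only one measured step speaks to a swap of this kind. The step of a 2.4-fold lower number from compound 1 to compound 3 (0.38 log units; beyond the scatter) replaced a hydroxy-bearing phenyl with pyridin-3-yl and gave a modest fall in the number. Going by the values given here, compound 4 reverses that direction, restoring a phenyl with a hydroxy group and adding a methoxy group, for which no measured step exists. A modest rise of the number, back toward the value of compound 1, is therefore the expectation, though the added methoxy group leaves the size uncertain.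

Compound 4 is thus estimated at 280000 nM, with a range from 120000 nM to 600000 nM, corresponding to an expected step of a 1.7-fold higher number from compound 3 to compound 4 (0.22 log units; within the scatter) in this assay.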

Compound 4, half-maximal inhibitory concentration: 303000 nM
For compound 4 the middle estimate is 1.1-fold (0.03 log units) below the measured one, within the range that was stated.
By their numbers in this assay, from the lowest: compounds 2, 3, 4 and 1 (each within the scatter of the next, the first and the last beyond it).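

In this assay, the position on a carbon with a double bond to nitrogen takes 2-hydroxy-5-methoxyphenyl, with 9 heavy atoms against the 6 of pyridin-3-yl, and the change stays within the scatter at a 1.8-fold higher number from compound 3 to compound 4 (0.26 log units; within the scatter); the comparison with the simpler 3-hydroxyphenyl also stays within the scatter, at a 1.3-fold lower number from compound 1 to compound 4 (0.12 log units; within the scatter). Only the comparison with 3-nitrophenyl goes beyond the scatter, and modestly, at a 2.5-fold higher number from compound 2 to compound 4 (0.41 log units; beyond the scatter), so the new group adds a third aryl comparison at this position in which the nitro compound stands apart from a hydroxy-bearing one, while compound 3 remains within the scatter of both compound 2 and compound 4. No measurement at hand accounts for these differences.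

The compounds shown leave open what the hydroxy and the methoxy groups of compound 4 each contribute on their own. They also leave open whether an amine or a carboxylic acid on the aromatic ring, or a saturated ring such as piperidine in place of it on this carbon, would shift the number further than any group seen so far.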